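The source may report more compounds than this note shows. Statements on the series, on what has been measured and on what is new or still open speak of the compounds shown alone.

In a functional assay on SK-BR-3 cells (Homo sapiens) for antiproliferative activity, read by MTT assay, with a stated time of 72 h (on this read-out lower numbers stand for stronger inhibition and higher numbers for weaker inhibition), compound 1 (`C/C=C1/[C@H](O[C@@H]2O[C@H](CO)[C@@H](O)[C@H](O)[C@H]2O)OC=C(C(=O)OC)[C@H]1CC(=O)OCCCCCCCCCCCCCCC`) gives 1600 nM. Compound 2 (`C/C=C1/[C@H](O[C@@H]2O[C@H](CO)[C@@H](O)[C@H](O)[C@H]2O)OC=C(C(=O)OC)[C@H]1CC(=O)OCc1ccc2c(c1)OCCO2`) gives > 15000 nM, which is a limit of the assay and not a number, so it stands at the limit with no measured potency. Compound 3 (`C/C=C1/[C@H](O[C@@H]2O[C@H](CO)[C@@H](O)[C@H](O)[C@H]2O)OC=C(C(=O)OC)[C@H]1CC(=O)OCCCc1ccc(OC)c(OC)c1`) has not yet been measured. Its change from compound 2 is 2-(3,4-dimethoxyphenyl)ethyl in place of 2,3-dihydro-1,4-benzodioxin-6-yl on a saturated chain carbon bound to an oxygen next to a carbonyl group. Among the compounds with values here, no measured step gauges this change, so the expectation rests on compound 2 alone, at > 15000 nM, again a limit. In this assay the expected step of a number no higher from compound 2 to compound 3 (the limit leaves the size open) stays within the scatter, with no direction favoured. Compound 3 is estimated at 15000 nM, with an expected range of 6000 nM to 40000 nM.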

Compound 3, half-maximal inhibitory concentration: > 20000 nM
Compound 3 gave a limit, no number; the forecaster's own chance of this, stated with the estimate: 55%; at least 1.3-fold (0.12 log units) between middle value and limit.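

In this assay compound 3 is a second entry that ends at a limit of the assay and not a number: the limit of > 20000 nM in this assay, at which 1 of the 3 values shown sits.

Within the data shown here, with 3,4-dimethoxyphenyl in place of dodecyl on a saturated chain carbon, three bonds along the chain from an oxygen next to a carbonyl group, the series shows an at least 12-fold higher number from compound 1 to compound 3 (1.09 log units; beyond the scatter), the only readable step at this position so far. The step between the two compounds that carry an aromatic ring cannot be read, as both are limits, so the 3,4-dimethoxyphenyl and 2,3-dihydro-1,4-benzodioxin-6-yl groups cannot be ranked against each other.

Neither limit tells how far compound 2 or compound 3 lies from a measurable value. Going by these compounds, what a shorter alkyl chain, a plain phenyl, an amine or a carboxylic acid would give at this position stays open.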